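The compounds below may be only part of what the source reports. "The series", "measured", "known", "first", "only" and "open" are said of these compounds alone.

Of the compounds shown here, three sharing one core have been tested in an ADME assay on RAW264.7 cells (Mus musculus) for cytotoxicity, read by MTT assay, with a stated time of 72 h, tested at 100 uM; on this read-out higher numbers stand for a stronger effect at the one concentration tested and lower numbers for a weaker effect. Compound 1 `O=C(Cn1c(=O)oc2cc([N+](=O)[O-])ccc21)Nc1ccccn1` gives 47.3%, compound 2 `O=C(Cn1c(=O)oc2ccccc21)NCc1ccccn1` gives 38.7%, and compound 3 `O=C(Cn1c(=O)oc2cc([N+](=O)[O-])ccc21)Nc1ccccc1` gives 26.4%, the lowest of the three. Among the measured compounds shown here, the only single-site step among them, phenyl in place of pyridin-2-yl on an amide-type nitrogen, is a number 20.9 percentage points lower from compound 1 to compound 3 (beyond the scatter). Compound 4 `O=C(Cn1c(=O)oc2ccccc21)Nc1ccccc1` differs from compound 3 by hydrogen in place of nitro on an aromatic carbon. For the measured compounds named here, no measured step isolates this change: compound 1 and compound 2 differ at that position but also elsewhere, and their two values lie within the scatter of each other. A small step downward, or none beyond the scatter, is therefore expected, a number 6.4 percentage points lower from compound 3 to compound 4 (within the scatter). For compound 4 in this assay the estimated value is 20%, expected to fall between 6% and 36%.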

Compound 4, a percentage reported as inhibition, at one concentration (the size of the read-out at that concentration, not a potency): 39.8%
For compound 4 the middle estimate is 19.8 percentage points below the measured one, outside the stated range (above it).
By their numbers in this assay, from the lowest: compound 3; then compounds 2, 4 and 1 (each within the scatter of the next).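

Among the compounds shown here, with phenyl on the amide-type nitrogen, the first clean reading of this position in this assay is that hydrogen in place of nitro gives a number 13.4 percentage points higher from compound 3 to compound 4 (beyond the scatter), so the nitro group does count here. Without nitro, phenyl in place of (pyridin-2-yl)methyl on that nitrogen gives a number 1.1 percentage points higher from compound 2 to compound 4 (within the scatter), so these two groups are not told apart. Nothing available explains the change at the nitro position.

Going by these compounds, it remains open whether the nitro step holds with pyridin-2-yl on the nitrogen. On these data alone, it is also open whether an amine or a carboxylic acid on that aromatic carbon would read like hydrogen or like nitro.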